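The source may report more compounds than this note shows. Statements on the series, on what has been measured and on what is new or still open speak of the compounds shown alone.

Of the compounds shown here, three have been measured in a functional assay on HT-29 cells (Homo sapiens) for cytotoxicity, read by MTT assay, with a stated time of 72 h; a lower number here means a stronger inhibitor of growth, a higher number a weaker inhibitor of growth. Compound 1 `CCOC(=O)Nc1ccc([Se][Se]c2ccc(NC(=O)OCC)cc2)cc1` gives 51100 nM in this assay. Compound 3 `CCCCCCOC(=O)Nc1ccc([Se][Se]c2ccc(NC(=O)OCCCCCC)cc2)cc1` shares its core with compound 1 but carries a longer chain; in this assay compound 3 gives 42600 nM, and that value and the value of compound 1 lie within the scatter of each other. Compound 2 `CC(C)COC(=O)Nc1ccc([Se]C#N)cc1` gives 31300 nM in this assay, the lowest of the three numbers, although its gaps to compound 3 and to compound 1 both fall within the scatter, so no ordering of the three can be claimed.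

Compound 4 `CCCCCCOC(=O)Nc1ccc([Se]C#N)cc1` has not yet been measured. It differs from compound 2 in one respect: pentyl in place of isopropyl on a saturated chain carbon bound to an oxygen next to a carbonyl group. Among the measured compounds shown here, no measured pair shows this step directly. For the measured compounds named here, the only guide is that compound 1 and compound 3, which differ from each other in chain length, give values within the scatter of each other. On that basis the expected step is a 1.1-fold lower number from compound 2 to compound 4 (0.05 log units; within the scatter), with no direction beyond the scatter. Compound 4 is therefore estimated to give 28000 nM in this assay, with a range from 12000 nM to 70000 nM.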

Compound 4, concentration for total growth inhibition: 40300 nM
Compound 4: the middle estimate sits 1.4-fold (0.16 log units) below what was measured, and the stated range covers the measured number.
By their numbers in this assay, from the lowest: compounds 2, 4, 3 and 1 (each within the scatter of the next).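

In this assay, pentyl in place of isopropyl on a saturated chain carbon bound to an oxygen next to a carbonyl group gives a 1.3-fold higher number from compound 2 to compound 4 (0.11 log units; within the scatter). Among the compounds shown here, this is the first direct reading of a change at this position, and it shows that going from isobutyl to hexyl on the core of compound 2 does not separate the two compounds in this assay. No evidence on the reason for this result is at hand.

The compounds shown leave open whether any group at this position can give a step beyond the scatter, such as a benzyl group, a chain longer than hexyl, or a chain ending in an amine or a carboxylic acid. They also leave open whether this same change would read alike in a different assay.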